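The source may report more compounds than this note shows. Statements on the series, on what has been measured and on what is new or still open speak of the compounds shown alone.

Compound 1, `O=C(/N=C(/NC(=O)c1cc(-c2ccccc2)nc2ccccc12)[Se]Cc1ccccc1)c1cc(-c2ccccc2)nc2ccccc12` — 47400 nM
Compound 2, `CS/C(=N\C(=O)c1cc(-c2ccccc2)nc2ccccc12)NC(=O)c1cc(-c2ccccc2)nc2ccccc12` — a limit only, > 100000 nM
Compound 3, `C[Se]/C(=N\C(=O)c1cc(-c2ccccc2)nc2ccccc12)NC(=O)c1cc(-c2ccccc2)nc2ccccc12` — not yet measured

In a functional assay on K562 cells (Homo sapiens) for cytotoxicity, read by MTT assay, with a stated time of 72 h (a higher number here means a weaker inhibitor of growth, a lower number a stronger inhibitor of growth), compound 1 gives 47400 nM. For compound 2 this assay reports no number, only the limit > 100000 nM. Going by these compounds, compound 2 therefore stands at the top edge of what was seen here, as noted in the limit of > 100000 nM in this assay, at which 1 of the 2 values shown sits; its true position is unknown beyond that.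

The change to compound 3 is a group of 2 heavy atoms (1 carbon, 1 selenium; no ring) in place of a group of 2 heavy atoms (1 carbon, 1 sulfur; no ring), on a carbon with a double bond to nitrogen. For the measured compounds named here, the only measured step that bears on it is an at least 2.1-fold higher number from compound 1 to compound 2 (0.32 log units; beyond the scatter), where a selenium-bearing group gave way to a sulfur-bearing one and the number rose at least modestly. Compound 3 returns selenium while keeping the short one-carbon chain of compound 2, so a step in the opposite direction, back toward compound 1, is expected, though smaller than the measured one: an at least 1.4-fold lower number from compound 2 to compound 3 (0.15 log units; that floor lies within the scatter) is the estimated change. Compound 3 is expected at 70000 nM, within 30000 nM to 160000 nM.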

Compound 3, concentration for total growth inhibition: 30600 nM
Compound 3: the middle estimate sits 2.3-fold (0.36 log units) above what was measured, and the stated range covers the measured number.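

In this assay, for the compounds shown here, the selenium-bearing group in place of methylsulfanyl, on a carbon with a double bond to nitrogen, gives an at least 3.2-fold lower number from compound 2 to compound 3 (0.51 log units; beyond the scatter), the first step here that exchanges sulfur for selenium with the chain length held constant. The value of compound 2, > 100000 nM, is a limit, so that step is only a floor: the limit of > 100000 nM in this assay, at which 1 of the 3 values shown sits. Hydrogen in place of phenyl on the saturated chain carbon bound to selenium gives a 1.5-fold lower number from compound 1 to compound 3 (0.19 log units; within the scatter), within the scatter, so among these compounds the difference follows the exchange of selenium for sulfur and not the phenyl.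

Open, going by these compounds, is whether a sulfur-bearing chain carrying phenyl would also stay weak in this assay. Also open, on these data alone, is whether selenium bearing a longer chain, an amine or a carboxylic acid would keep this level of growth inhibition.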